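The source may hold more compounds than are shown below. What is called first, only, known or untested is meant among the compounds shown, and "the series" means these compounds.

In a functional assay on BXPC-3 cells (Homo sapiens) for inhibition, read by XTT assay, with a stated time of 72 h (a lower number here means a stronger inhibitor, a higher number a weaker inhibitor), compound 1 `CCCCCCCC/C=C\CCCCCCCCOC[C@@H]1CCCN1` gives 5300 nM. Compound 2 `CCCCCCCC/C=C/CCCCCCCCOC[C@@H]1CCCN1` gives 5300 nM, so compound 1 stands level with it. These two compounds differ only in the configuration drawn at the double bond, as the fact that compounds 1 and 2 differ only in the configuration as drawn records, and the measured step is no change at the digits printed from compound 1 to compound 2 (within the scatter). Compound 3 `CC(C)(C)OC(=O)N1CCC[C@H]1COCCCCCCCC/C=C/c1ccc(Oc2ccccc2)cc1` gives > 100000 nM, which is a limit of the assay and not a number.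

The next compound to consider is compound 4 `CCCCCCCC/C=C\CCCCCCCCOC[C@@H]1CCCN1C(=O)CN`. It carries (aminomethyl)carbonyl in place of hydrogen on an amine nitrogen in a ring, and the change counts as (aminomethyl)carbonyl in place of hydrogen on an amine nitrogen in a ring. Among the measured compounds shown here, the only measured step, no change at the digits printed from compound 1 to compound 2 (within the scatter), concerns the double bond and not this nitrogen, so it gives no direct size for the new change. For the measured compounds named here, no single-place step links compound 3 to compound 1 either. The expected direction is therefore only a cautious lean towards weaker inhibition, resting loosely on compound 3 and its limit of > 100000 nM. The expected step is a 2.5-fold higher number from compound 1 to compound 4 (0.39 log units; beyond the scatter), a modest weakening with wide uncertainty. For compound 4 the estimated value in this assay is 13000 nM, with an expected range from 3000 nM to 50000 nM.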

Compound 4, half-maximal inhibitory concentration: 5300 nM
The estimate for compound 4 lay 2.5-fold (0.39 log units) above the measured number, within the range that was stated.
By their numbers in this assay, from the lowest: compounds 1, 2 and 4 (each within the scatter of the next). At a limit, above all of these: compound 3.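

In this assay, among the compounds shown here, the first measured change at this nitrogen, (aminomethyl)carbonyl in place of hydrogen on the amine nitrogen in the ring, gives no change at the digits printed from compound 1 to compound 4 (within the scatter) and so leaves the reading where it was. Until now, the only step between two compounds differing in one place concerned the double bond in the chain, so nothing had shown what happens when this nitrogen is altered. This step shows that the hydrogen on this nitrogen can be replaced by this one group with no measurable loss in these cells, though nothing measured here explains why the number holds.

The compounds shown leave open whether other groups on this nitrogen, such as a plain acetyl, a longer chain ending in an amine, or a chain ending in a carboxylic acid, would also leave the number in place or would move it. They also leave open whether (aminomethyl)carbonyl would behave the same way on compound 2, where the double bond is drawn E instead of Z.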